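The compounds below may be only part of what the source reports. "The series", "measured", "known", "first", "only" and "open" are said of these compounds alone.

Three compounds share one core and differ only in a single group carried on a six-membered aromatic ring of carbon only. In an ADME assay on microsomes from liver (Homo sapiens) for metabolic stability, with a stated time of 10 min (a higher number here means that more of the compound is left, a lower number that less of the compound is left), compound 1 `COc1cc(OCc2cccc(COc3ccccc3)c2)c2cc(-c3cn4nc(OC)sc4n3)oc2c1` gives 86%, compound 2 `COc1cc(OCc2cccc(O)c2)c2cc(-c3cn4nc(OC)sc4n3)oc2c1` gives 97%, and compound 3 `COc1cc(OCc2cccc(C#N)c2)c2cc(-c3cn4nc(OC)sc4n3)oc2c1` gives 100%. Compound 3 stands at the top of these three numbers, though its gap to compound 2 lies within the scatter, while the step of a number 14 percentage points higher from compound 1 to compound 3 (beyond the scatter) lies beyond it, as does a number 11 percentage points higher from compound 1 to compound 2 (beyond the scatter). Compound 4 `COc1cc(OCc2cccc(Oc3ccccc3)c2)c2cc(-c3cn4nc(OC)sc4n3)oc2c1` has yet to be measured; it differs from compound 3 by phenoxy in place of cyano on an aromatic carbon. The step that bears on this change is a number 14 percentage points higher from compound 1 to compound 3 (beyond the scatter). Compound 1 carries a phenoxymethyl group, a close relative of the phenoxy group that enters here. The step of a number 3 percentage points higher from compound 2 to compound 3 (within the scatter) shows only that hydroxy and cyano sit within the scatter of each other. Reversing that relevant step, the expected change in this assay is a modest fall, estimated at a number 14 percentage points lower from compound 3 to compound 4 (beyond the scatter). Compound 4 is therefore expected to give about 86%, with a range from 72% to 98%.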

Compound 4, percent of the compound remaining: 86%
Compound 4: middle estimate and measured number agree at the digits printed; low and high end bracket the measured number.
By their numbers in this assay, from the lowest: compounds 1 and 4 (each within the scatter of the next); then compounds 2 and 3 (each within the scatter of the next).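

In this assay, shortening phenoxymethyl to phenoxy at this position makes no difference, with no change at the digits printed from compound 1 to compound 4 (within the scatter), so the two groups cannot be told apart here. The fall seen earlier with phenoxymethyl now appears with a second group that carries an outer six-membered aromatic ring of carbon only: there is a number 14 percentage points lower from compound 3 to compound 4 (beyond the scatter), and placing phenyl on the oxygen of the hydroxy group gives a number 11 percentage points lower from compound 2 to compound 4 (beyond the scatter). Nothing available explains why these changes leave less of the compound at the end of the assay.

Going by these compounds, it remains open whether the size of the group or the outer ring itself goes with the lower number. A pyridyloxy group, with nitrogen in that outer ring, or a small amine or carboxylic acid at this position could help to separate these possibilities.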